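This account rests on a few compounds, and the source may have more. Where it says the series, first, only, none or still open, it means among the compounds named here.

Compound 1 `OC[C@H]1O[C@@H](n2cnc3c(NCc4ccc(Cl)cc4)ncnc32)[C@H](O)[C@@H]1O`: in a functional assay on K562 cells (Homo sapiens) for antiproliferative activity, with a stated time of 72 h (on this read-out higher numbers stand for weaker inhibition and lower numbers for stronger inhibition), compound 1 gives 218000 nM.
Compound 2 `Cc1ccc(CNc2ncnc3c2ncn3[C@@H]2O[C@H](CO)[C@@H](O)[C@H]2O)cc1`: in this assay compound 2 reaches only the limit > 166000 nM, a limit of the assay rather than a number.
Compound 3 `COc1ccc(CNc2ncnc3c2ncn3[C@@H]2O[C@H](CO)[C@@H](O)[C@H]2O)c(OC)c1`: in this assay compound 3 likewise stops at the limit > 166000 nM, again a limit and not a number.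

Compound 3 thus stands at a limit, and a second of the three values shown sits at the same point (the limit of > 166000 nM in this assay, at which 2 of the 3 values shown sit). The change leading to compound 4 `COc1cccc(CNc2ncnc3c2ncn3[C@@H]2O[C@H](CO)[C@@H](O)[C@H]2O)c1O` is 2-hydroxy-3-methoxyphenyl in place of 2,4-dimethoxyphenyl on a saturated chain carbon bound to a nitrogen on an aromatic ring. The measured steps that touch compound 3 are a step that the limit leaves unreadable from compound 1 to compound 3 and a step that the two limits leave unreadable from compound 2 to compound 3; both are left unreadable in size by the limit, as is a step that the limit leaves unreadable from compound 1 to compound 2. With nothing readable to build on, no step beyond the scatter is expected in this assay in either direction. Compound 4 is estimated to remain near the same limit, the expected step being a step that the limit leaves unreadable from compound 3 to compound 4. Compound 4 is therefore expected to give about 200000 nM, between 100000 nM and 400000 nM, most likely reported once more as a limit.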

Compound 4, half-maximal inhibitory concentration: 27900 nM
Beside the measured number, compound 4's estimate is 7.2-fold (0.86 log units) above it; the measured number lies below the stated range.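

In this assay, the group on the saturated chain carbon bound to a nitrogen on an aromatic ring gives its first readable effect with 2-hydroxy-3-methoxyphenyl: in place of 2,4-dimethoxyphenyl it brings an at least 5.9-fold lower number from compound 3 to compound 4 (0.77 log units; beyond the scatter), and in place of 4-methylphenyl it brings an at least 5.9-fold lower number from compound 2 to compound 4 (0.77 log units; beyond the scatter). In place of 4-chlorophenyl it brings a 7.8-fold lower number from compound 1 to compound 4 (0.89 log units; beyond the scatter), whereas the steps among compounds 1, 2 and 3 cannot be read. Among these compounds, this position therefore responds to a change of aryl group, and the one compound here with a hydrogen-bond donor in that group is also the one that stands apart.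

The compounds shown leave open whether the hydroxy group alone accounts for these steps, or whether the methoxy group shares in them. They also leave open how an amine or a carboxylic acid in place of that hydroxy group would read out.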